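Swapping the Amide Side Group of Compound 3

The compounds below may be only part of what the source reports. "The series", "measured", "known", "first", "only" and "open" are said of these compounds alone.

Three compounds have been measured in a functional assay on Venous blood for antagonist activity at C-X-C chemokine receptor type 3 (Homo sapiens), read by flow cytometry, with a stated time of 30 min, in the presence of a further agent that is not named here; a lower number here means a stronger inhibitor, a higher number a weaker inhibitor:
Compound 1, `Cc1nc(C)n(CC(=O)N2CCN(c3sc(C(F)(F)F)nc3-c3nc4ccc(C5CCN(C)CC5)cc4[nH]3)C[C@H]2C)n1`, gives 84.7 nM.
Compound 2, `C[C@@H]1CN(c2sc(C(F)(F)F)nc2-c2nc3ccc(CO)cc3[nH]2)CCN1C(=O)Cn1cnc2cccnc21`, gives 92.4 nM.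
Compound 3, `C[C@@H]1CN(c2sc(C(F)(F)F)nc2-c2nc3ccccc3[nH]2)CCN1C(=O)Cn1cc(C2CCN(C)CC2)cn1`, gives 1690 nM.

Compound 3 stands at the highest of the three numbers, which here means it is the weakest inhibitor of the set. Its gap to compound 2 and its gap to compound 1 both lie well beyond the scatter of repeated measurements, so its weaker activity is real and not noise. All three share the same core; they differ in the groups hanging off it.

Compound 4, `C[C@@H]1CN(c2sc(C(F)(F)F)nc2-c2nc3ccccc3[nH]2)CCN1C(=O)CN1C(=O)OC[C@@H]1c1ccccc1`, has not yet been measured. It keeps the core of compound 3 and changes only the group on the amide side chain: 2-oxo-4-phenyl-1,3-oxazolidin-3-yl in place of 4-(1-methylpiperidin-4-yl)-1H-pyrazol-1-yl on a saturated chain carbon bound to a carbonyl carbon. Among the measured compounds shown here, no measured pair in this set shows this exact change, so nothing here tells directly what it will do. The two more potent compounds carry a flat, nitrogen-rich ring at that position, as does compound 3, so the ring type alone does not explain the spread. With that uncertainty, a modest drop in the number, beyond the scatter, is expected from compound 3 to compound 4 (a 2.8-fold lower number from compound 3 to compound 4 (0.45 log units; beyond the scatter)). Compound 4 is expected to give about 600 nM in this assay, within a range from 150 nM to 2500 nM.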

Compound 4, half-maximal inhibitory concentration: 1380 nM
Compound 4: the middle estimate sits 2.3-fold (0.36 log units) below what was measured, within the range that was stated.
By their numbers in this assay, from the lowest: compounds 1 and 2 (each within the scatter of the next); then compounds 4 and 3 (each within the scatter of the next).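

Among the compounds shown here, putting 2-oxo-4-phenyl-1,3-oxazolidin-3-yl in place of 4-(1-methylpiperidin-4-yl)-1H-pyrazol-1-yl on a saturated chain carbon bound to a carbonyl carbon gives a 1.2-fold lower number from compound 3 to compound 4 (0.09 log units; within the scatter) in this assay and this is the only step in the set that changes a single place. The two groups have the same count of heavy atoms but are built differently: the group that leaves has an aromatic five-membered ring and a non-aromatic six-membered ring, while the group that enters has a non-aromatic five-membered ring, a carbon-only aromatic six-membered ring and a defined stereocentre, so on this core the position accepts a large change of ring make-up with no readable shift in the number. Nothing available here explains why the number stays put.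

A single step cannot show whether this position responds to any group at all, and a much smaller group in the same place, such as a primary amine or a carboxylic acid, would test that more sharply. Also open, from the compounds shown here alone, is what the opposite arrangement at the stereocentre of the 2-oxo-4-phenyl-1,3-oxazolidin-3-yl group would give.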